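Methyl to trifluoromethyl on an antiproliferative compound

A few compounds are considered here, and "the series" means these few. Any claim that something is new, unique, unknown or untested is made for them only; others in the source may bear on it.

Compound 1 `CNc1nc(-c2cc(OC)c(OC)c(OC)c2)c(-c2ccc(C(F)(F)F)cc2)s1`: 1240 nM
Compound 2 `COc1cc(-c2nc(C)sc2-c2ccc(C)cc2)cc(OC)c1OC`: 722 nM

In a functional assay on HT-29 cells (Homo sapiens) for antiproliferative activity, read by MTT assay, with a stated time of 72 h (a higher number here means a weaker inhibitor, a lower number a stronger inhibitor), compound 2 gives 722 nM, within the usual scatter of compound 1 at 1240 nM, so the two cannot be told apart. Compound 3 `COc1cc(-c2nc(C)sc2-c2ccc(C(F)(F)F)cc2)cc(OC)c1OC` differs from compound 2 by trifluoromethyl in place of methyl on an aromatic carbon. Going by the values given here, no measured pair isolates this change. Compound 1 also carries trifluoromethyl and gives 1240 nM, so no large shift is expected in this assay. The estimated step of a 1.2-fold higher number from compound 2 to compound 3 (0.10 log units; within the scatter) is expected to stay within the scatter. For compound 3 the estimate is 900 nM, with an expected range from 300 nM to 2700 nM.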

Compound 3, half-maximal inhibitory concentration: 396 nM
Compound 3: the middle estimate sits 2.3-fold (0.36 log units) above what was measured, and the stated range covers the measured number.
By their numbers in this assay, from the lowest: compounds 3, 2 and 1 (each within the scatter of the next, the first and the last beyond it).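

In this assay, trifluoromethyl in place of methyl on this aromatic carbon gives a 1.8-fold lower number from compound 2 to compound 3 (0.26 log units; within the scatter) and so no shift that can be told apart from the scatter. With trifluoromethyl kept, methyl in place of methylamino gives a 3.1-fold lower number from compound 1 to compound 3 (0.50 log units; beyond the scatter) as a modest step, the only one here that clears the scatter. Nothing shown here explains either step. On these data alone, whether a chlorine atom or a nitrile at the trifluoromethyl position would behave the same remains open. So does whether an amine or a longer chain in place of the methyl would keep compound 3 in this range.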